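This account rests on a few compounds, and the source may have more. Where it says the series, first, only, none or still open, it means among the compounds named here.

Measured in a physicochemical assay for solubility; on this read-out higher numbers stand for higher solubility and lower numbers for lower solubility:
Compound 1 `CNC(=O)c1cc(C(=O)NC2CC2)cn(Cc2ccc(OC)cc2)c1=O`: >= 143 ug/mL (a limit)
Compound 2 `CNC(=O)c1cc(C(=O)NCCCC2CNCCO2)cn(Cc2ccccc2)c1=O`: >= 194 ug/mL (a limit)
Compound 3 `CNC(=O)c1cc(C(=O)NC2CC2)cn(Cc2ccc(C)cc2)c1=O`: 24 ug/mL

Compound 3, at 24 ug/mL, is the only one of the three with an actual number. The other two values are limits. Compound 4 `CNC(=O)c1cc(C(=O)NC2CC2)cn([C@H](C)c2ccccc2)c1=O` carries 1-phenylethyl in place of 4-methylbenzyl on an aromatic nitrogen. Within the data shown here, the one measured step, an at least 5.9-fold lower number from compound 1 to compound 3 (0.77 log units; beyond the scatter), is methyl in place of methoxy on an aromatic carbon. It is a different change and bears on this one only loosely, showing that this assay can move beyond the scatter within this series. Among the measured compounds shown here, no measured step tests the new group directly. The estimated change is a 1.7-fold higher number from compound 3 to compound 4 (0.22 log units; within the scatter), a small expected rise that may stay within the scatter. For compound 4 the expected value is 40 ug/mL, with an estimated range of 15 ug/mL to 110 ug/mL.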

Compound 4, solubility: >= 168 ug/mL
Compound 4: a limit, no number; the forecaster's own chance of this, stated with the estimate: 10%; middle value at least 4.2-fold (0.62 log units) away from the limit.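

Replacing 4-methylbenzyl with 1-phenylethyl on the aromatic nitrogen gives an at least 7.0-fold higher number from compound 3 to compound 4 (0.84 log units; beyond the scatter) in this assay. The earlier step changed a group on an aromatic carbon, whereas this one shows that the same atoms, joined differently at this nitrogen, can move the number beyond the scatter. Compound 4 gives a limit and not a number, so the full size of the step stays unknown: the limit of >= 168 ug/mL in this assay, at which 1 of the 4 values shown sits.

The compounds shown do not separate the loss of the ring methyl from the gain of the branching methyl. Also open, from the compounds shown here alone, is how the other stereoisomer of 1-phenylethyl, or a 1-phenylethyl carrying a carboxylic acid on its ring, would read.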